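Swapping pyridin-2-yl for 1,3-thiazol-2-yl on the amide

The source may report more compounds than this note shows. Statements on the series, on what has been measured and on what is new or still open speak of the compounds shown alone.

In a functional assay on A549 cells (Homo sapiens) for inhibition, read by MTT assay, with a stated time of 72 h (on this read-out lower numbers stand for stronger inhibition and higher numbers for weaker inhibition), compound 1 `CC(C)c1ccc(NC(=O)C2CCN(C/C=C/c3ccccc3)CC2)cc1` gives 9430 nM. Among the measured compounds shown here, compound 2 `O=C(Nc1ccccn1)C1CCN(C/C=C/c2ccccc2)CC1` gives 89300 nM, the higher of the two numbers so far and therefore the weaker inhibition. Compound 3 `O=C(Nc1nccs1)C1CCN(C/C=C/c2ccccc2)CC1` awaits measurement. It differs from compound 2 in one place, on an amide-type nitrogen, with 1,3-thiazol-2-yl in place of pyridin-2-yl on an amide-type nitrogen.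

For the measured compounds named here, the only measured step at this place is a 9.5-fold higher number from compound 1 to compound 2 (0.98 log units; beyond the scatter), which put pyridin-2-yl in place of 4-isopropylphenyl. That step, modest but beyond the scatter, shows that the place can move the number. It offers no comparison of two aromatic rings bearing hetero atoms, so its direction does not carry over. A smaller step is expected here, leaning weakly towards a lower number. The estimated step is a 1.5-fold lower number from compound 2 to compound 3 (0.17 log units; within the scatter). Compound 3 is expected at 60000 nM, with an estimated range of 20000 nM to 150000 nM.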

Compound 3, half-maximal inhibitory concentration: 34900 nM
Compound 3: middle estimate off by 1.7-fold (0.24 log units), on the high side; the range from low to high includes it.
By their numbers in this assay, from the lowest: compound 1; then compound 3; then compound 2.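

In this assay, two aromatic rings bearing hetero atoms can now be compared directly on the amide-type nitrogen: 1,3-thiazol-2-yl in place of pyridin-2-yl gives a 2.6-fold lower number from compound 2 to compound 3 (0.41 log units; beyond the scatter), so this place also separates these two rings, not only pyridin-2-yl from 4-isopropylphenyl. Neither of these rings matches 4-isopropylphenyl, since 1,3-thiazol-2-yl still gives a 3.7-fold higher number from compound 1 to compound 3 (0.57 log units; beyond the scatter), leaving compound 1 with the lowest number of the three. No measurement at hand accounts for this order.

Open, from the compounds shown here alone, is where a plain phenyl, or a 1,3-thiazol-2-yl ring carrying a methyl group or a carboxylic acid, would fall relative to these three groups. Also open, going by these compounds, is whether the same order holds on cells other than A549.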